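Extending the Hydroxy Group of Compound 1

A few compounds are considered here, and "the series" means these few. Any claim that something is new, unique, unknown or untested is made for them only; others in the source may bear on it.

Three compounds have been measured in a functional assay on CRL2813 cells (Homo sapiens) for cytotoxicity, read by sulforhodamine B assay, with a stated time of 5 days; a higher number here means a weaker inhibitor, a lower number a stronger inhibitor:

Compound 1, `O=C(Nc1cccc(C(F)(F)F)c1)N[C@H]1CC[C@H](O)CC1`, gives > 20000 nM, which is a limit of this assay rather than a number.
Compound 2, `CSc1ccc(NC(=O)N[C@H]2CC[C@H](Oc3ccc(F)cc3)CC2)cc1`, gives > 20000 nM, again a limit.
Compound 3, `Cc1ccccc1NC(=O)N[C@H]1CC[C@H](Oc2ccc(F)cc2)CC1`, gives > 20000 nM, again a limit.

Compound 1 therefore stands nowhere in particular on the numbers shown: only a limit is known for it, and the same holds for the two other compounds, so that the limit of > 20000 nM in this assay, at which 3 of the 3 values shown sit, describes the whole set. For the measured compounds named here, the one step between measured compounds, a step that the two limits leave unreadable from compound 2 to compound 3, is unreadable for the same reason.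

Compound 4, `O=C(Nc1cccc(C(F)(F)F)c1)N[C@H]1CC[C@H](OCc2ccc(F)cc2)CC1`, differs from compound 1 by 4-fluorobenzyl in place of hydrogen on an oxygen on a saturated carbon. Going by the values given here, no measured step bears on this change in a readable way; the only guidance is that compounds 2 and 3, which also carry an aryl-bearing substituent on that oxygen, sit at the limit. Compound 4 is thus expected to remain at or near the limit, with a step that the limit leaves unreadable from compound 1 to compound 4, and its value in this assay is estimated at 30000 nM within 8000 nM to 100000 nM.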

Compound 4, half-maximal inhibitory concentration: 2650 nM
For compound 4 the middle estimate is 11-fold (1.05 log units) above the measured one, and the stated range ends above it.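

In this assay, for the compounds shown here, 4-fluorobenzyl in place of hydrogen on the oxygen gives an at least 7.5-fold lower number from compound 1 to compound 4 (0.87 log units; beyond the scatter), the first step in the set that can be read and one beyond the scatter. This shows that the oxygen on the saturated carbon can take a substituent with a six-membered aromatic ring and that, on the core of compound 1, this change moves the value off the limit. Compound 4 remains the only compound shown with a measured number, which leaves this single step as the readable result: the limit of > 20000 nM in this assay, at which 3 of the 4 values shown sit.

As far as these compounds go, it remains open whether the fluorine, the aromatic ring or simply a larger group on that oxygen accounts for the step, which a plain benzyl, a methyl or a longer chain ending in an amine could help to separate. Also open, from the compounds shown here alone, is whether the same change has a similar size with a different aryl group on the amide-type nitrogen.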